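Trimming Naphthyl to Phenyl on a Thiourea Side Chain

The compounds below may be only part of what the source reports. "The series", "measured", "known", "first", "only" and "open" are said of these compounds alone.

Compound 1 `O=c1ccc(-c2ccccc2)nn1CCCCNC(=S)Nc1cccc2ccccc12` carries a thiourea tail on the shared core. In a functional assay on the whole organism (stomach) with Rattus norvegicus as the target (on this read-out higher numbers stand for an effect only at larger amounts of compound and lower numbers for an effect already at smaller amounts), compound 1 gives > 100 mg/kg, which is a limit of the assay rather than a number (the limit of > 100 mg/kg in this assay, at which 1 of the 2 values shown sits). Compound 2 `C/N=C(\S)NCCCCCn1nc(-c2ccccc2)ccc1=O`, built around a different tail, gives 35.3 mg/kg in this assay. Compound 3 `O=c1ccc(-c2ccccc2)nn1CCCCNC(=S)Nc1ccccc1` differs from compound 1 by phenyl in place of naphthalen-1-yl on an amide-type nitrogen. Among the compounds with values here, since no measured step of this kind exists, the step is expected to be an at least 1.1-fold lower number from compound 1 to compound 3 (0.04 log units; that floor lies within the scatter), most likely no larger than the usual scatter. Compound 3 is therefore expected to give 90 mg/kg, with a plausible range from 35 mg/kg to 250 mg/kg.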

Compound 3, dose for half-maximal effect: > 100 mg/kg
Compound 3: no number, only a limit (the forecaster's own chance of this, stated with the estimate: 50%); at least 1.1-fold (0.04 log units) between middle value and limit.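

Compound 1 and compound 3 both end at a limit of this assay rather than a number, so no step can be read between them: the limit of > 100 mg/kg in this assay, at which 2 of the 3 values shown sit.

The compounds shown leave open whether phenyl in place of naphthalen-1-yl changes the dose needed at all.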